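This account rests on a few compounds, and the source may have more. Where it says the series, first, only, none or still open, it means among the compounds named here.

Compound 1 `COc1ccc(N/C(CCNC2=CC(=O)c3ccccc3C2=O)=N\S(=O)(=O)c2ccc(C)cc2)cc1OC` stands highest of the three numbers measured in a functional assay on HeLa cells (Homo sapiens) for cytotoxicity, read by MTT assay, with a stated time of 48 h (a lower number here means a stronger inhibitor, a higher number a weaker inhibitor), where compound 1 gives 14500 nM. Compound 2 `COc1ccc(N/C(CCNC2=C(Br)C(=O)c3ccccc3C2=O)=N\S(=O)(=O)c2ccc(C)cc2)cc1OC` gives 5370 nM, a step that reads a 2.7-fold lower number from compound 1 to compound 2 (0.43 log units; beyond the scatter). Compound 3 `COc1ccc(N/C(CCNC2=CC(=O)c3ccccc3C2=O)=N\S(=O)(=O)c2ccc(C(C)(C)C)cc2)cc1OC` gives 11500 nM, a step that reads a 1.3-fold lower number from compound 1 to compound 3 (0.10 log units; within the scatter).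

Compound 4 `Cc1ccc(S(=O)(=O)/N=C(\N)CCNC2=CC(=O)c3ccccc3C2=O)cc1` differs from compound 1 in one place: hydrogen in place of 3,4-dimethoxyphenyl on an amine nitrogen. Neither measured step touches this amine nitrogen, so both are only a loose guide; the larger of them was modest and the other lay within the scatter. The step to compound 4 is therefore expected to be small, as a 1.2-fold higher number from compound 1 to compound 4 (0.09 log units; within the scatter), with no clear direction beyond the scatter. Compound 4 is expected to give about 18000 nM, within a range from 6000 nM to 55000 nM.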

Compound 4, half-maximal inhibitory concentration: 24600 nM
Compound 4: the middle estimate sits 1.4-fold (0.14 log units) below what was measured; the measured number falls inside the stated range.
By their numbers in this assay, from the lowest: compound 2; then compounds 3, 1 and 4 (each within the scatter of the next, the first and the last beyond it).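

In this assay, removing the entire 3,4-dimethoxyphenyl from the amine nitrogen gives a 1.7-fold higher number from compound 1 to compound 4 (0.23 log units; within the scatter). Within the data shown here, the earlier steps changed other parts of the molecule, so this is the first sign that a whole aromatic ring with its two methoxy groups can go from this nitrogen without a change beyond the scatter. No available evidence explains this result. As far as these compounds go, whether a methyl, a plain phenyl or a longer alkyl chain on this nitrogen would move the number remains open. So does whether bromo in place of hydrogen on the double-bonded ring carbon would give a similar step in compound 4.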